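Removing the methyl from the core of compound 1

This account rests on a few compounds, and the source may have more. Where it says the series, first, only, none or still open, it means among the compounds named here.

Among the measured compounds shown here, compound 1, with the structure `CCCCCc1cc2nn(-c3ccccc3)cc2c(C)n1`, is the only member of this small set that gives a true number in a functional assay on MCF7 cells (Homo sapiens) for inhibition, read by fluorescence, with a stated time of 72 h (a higher number here means a weaker inhibitor of growth, a lower number a stronger inhibitor of growth), where compound 1 gives 17000 nM. Compound 2, of structure `Cc1nc(CCO)cc2nn(-c3ccccc3)cc12`, reaches only the limit of > 100000 nM in this assay. Compound 3, of structure `Cc1nccc2nn(-c3ccccc3)cc12`, likewise stops at the limit of > 100000 nM in this assay. Both changes from compound 1 thus cost activity: an at least 5.8-fold higher number from compound 1 to compound 2 (0.76 log units; beyond the scatter), and an at least 5.8-fold higher number from compound 1 to compound 3 (0.76 log units; beyond the scatter). The step between compound 2 and compound 3 is a step that the two limits leave unreadable from compound 2 to compound 3.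

Compound 4, of structure `CCCCCc1cc2nn(-c3ccccc3)cc2cn1`, differs from compound 1 by hydrogen in place of methyl on an aromatic carbon. Neither measured step touches this methyl, so the two steps bear only indirectly: each shows that the shared core of compound 1 tolerates little pruning, since the limit of > 100000 nM in this assay, at which 2 of the 3 values shown sit, is where both altered compounds end up. The present change is a single carbon, smaller than either measured loss, so a smaller step is expected; compound 4 is expected to be a somewhat weaker inhibitor, with a step of a 2.1-fold higher number from compound 1 to compound 4 (0.31 log units; beyond the scatter). Compound 4 is therefore estimated at 35000 nM, within a range from 12000 nM to 100000 nM.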

Compound 4, concentration for 50% growth inhibition: 11800 nM
Beside the measured number, compound 4's estimate is 3.0-fold (0.47 log units) above it; the measured number lies below the stated range.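

Replacing the methyl by hydrogen on this aromatic carbon gives a 1.4-fold lower number from compound 1 to compound 4 (0.16 log units; within the scatter) in this assay, so the two compounds cannot be told apart in this read-out. The earlier steps shown here did not touch this position, and the new step shows that this methyl, next to the ring nitrogen and ortho to a fused ring, is not required for the growth inhibition seen with compound 1; the shared core can lose this one carbon without a readable change, even though the other changes to compound 1 went beyond the scatter. Compound 2 and compound 3, which carry no pentyl group, remain at a limit of the assay rather than at a number, so the pentyl group is present in every compound that gives a number here: the limit of > 100000 nM in this assay, at which 2 of the 4 values shown sit.

What the compounds shown leave open is whether this position accepts anything larger than methyl, such as an ethyl, a methoxy or an amine, with hydrogen and methyl being the only two groups compared here. From the compounds shown here alone, it also remains open how the number responds at the pentyl position to a longer chain, or to a carboxylic acid at the end of that chain.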